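Swapping phenyl for pyridin-4-yl on the carbonyl

A few compounds are considered here, and "the series" means these few. Any claim that something is new, unique, unknown or untested is made for them only; others in the source may bear on it.

Measured so far in an ADME assay on HEK-293T cells (Homo sapiens) for cytotoxicity, read by MTT assay, with a stated time of 24 h; a higher number here means that more compound is tolerated, a lower number that less compound is tolerated:
- compound 1 `Cc1ccc(-c2nn(-c3ccccc3)cc2-c2nc3ccccc3n2C(=O)c2ccccc2)cc1`: 204000 nM
- compound 2 `O=C(c1ccccc1)n1c(-c2cn(-c3ccccc3)nc2-c2ccc(C(F)(F)F)cc2)nc2ccccc21`: 168000 nM

For the measured compounds named here, compound 1 gives the highest of the two numbers in this assay, but its only neighbour, compound 2, sits so close that the step of a 1.2-fold lower number from compound 1 to compound 2 (0.08 log units; within the scatter) lies within the scatter, so the two are not distinguishable here.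

Compound 3 `Cc1ccc(-c2nn(-c3ccccc3)cc2-c2nc3ccccc3n2C(=O)c2ccncc2)cc1` is the next compound to be measured. It differs from compound 1 by pyridin-4-yl in place of phenyl on a carbonyl carbon. Going by the values given here, the one measured step, a 1.2-fold lower number from compound 1 to compound 2 (0.08 log units; within the scatter), concerns a different group at a different place, so no measured step bears on this change, and it was itself within the scatter. With nothing pointing either way, the step from compound 1 to compound 3 is expected to be a 1.0-fold lower number from compound 1 to compound 3 (0.01 log units; within the scatter), that is, none beyond the scatter. Compound 3 is therefore estimated at 200000 nM, with a range from 100000 nM to 400000 nM.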

Compound 3, half-maximal cytotoxic concentration: 154000 nM
Compound 3: the middle estimate sits 1.3-fold (0.11 log units) above what was measured; low and high end bracket the measured number.
By their numbers in this assay, from the lowest: compounds 3, 2 and 1 (each within the scatter of the next).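

For the compounds shown here, the earlier step concerned only the group on an aromatic carbon, so this is the first reading of a change on the carbonyl carbon. In this assay the swap gives a 1.3-fold lower number from compound 1 to compound 3 (0.12 log units; within the scatter), which cannot be told apart from no change. At this place, then, a ring of carbon only can give way to a ring with one hetero atom and one hydrogen-bond acceptor without a readable shift in the tolerated concentration, at least on the core of compound 1. Nothing available explains this result.

As far as these compounds go, whether the same holds for pyridin-3-yl, for an open alkyl chain or for an amine on the carbonyl carbon remains open. So does whether pyridin-4-yl would read the same alongside the trifluoromethyl group of compound 2.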